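This account rests on a few compounds, and the source may have more. Where it says the series, first, only, none or still open, it means among the compounds named here.

In a functional assay (aorta) with Oryctolagus cuniculus as the target (on this read-out higher numbers stand for weaker inhibition and lower numbers for stronger inhibition), compound 3 `CC1=C(C)C(=O)C(C(CCCCCC(=O)O)c2cccc(F)c2)=C(C)C1=O` gives 1900 nM and lies within the usual scatter of the two other measured compounds. Compound 1 `CC1=C(C)C(=O)C(C(CCCCCCC(=O)O)c2ccccc2)=C(C)C1=O` gives 3200 nM on the same read-out, and compound 2 `CC1=C(C)C(=O)C(C(CCCCCCCC(=O)O)c2ccccc2)=C(C)C1=O` gives 3400 nM there. Compound 4 `CC1=C(C)C(=O)C(C(CCCCCC(=O)O)c2cccs2)=C(C)C1=O` carries thiophen-2-yl in place of 3-fluorophenyl on a saturated chain carbon bound to a double-bonded ring carbon and a saturated chain carbon. Among the compounds with values here, the one measured step is a 1.1-fold higher number from compound 1 to compound 2 (0.03 log units; within the scatter) and it changes only the chain, so no measurement tests this swap directly. The expected step in this assay is therefore a 1.2-fold higher number from compound 3 to compound 4 (0.06 log units; within the scatter) and none beyond the scatter. For compound 4 the estimated value is 2200 nM with an expected range from 900 nM to 5000 nM for this estimate.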

Compound 4, half-maximal inhibitory concentration: 760 nM
Compound 4: middle estimate off by 2.9-fold (0.46 log units), on the high side; the measured number lies below the stated range.
By their numbers in this assay, from the lowest: compound 4; then compounds 3, 1 and 2 (each within the scatter of the next).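

In this assay, placing thiophen-2-yl where 3-fluorophenyl stood gives a 2.5-fold lower number from compound 3 to compound 4 (0.40 log units; beyond the scatter), so the aromatic group on this saturated chain carbon can shift the number beyond the scatter. The earlier chain step, a 1.1-fold higher number from compound 1 to compound 2 (0.03 log units; within the scatter), stayed within the scatter and could not show this. No measurement here gives a reason for the new step.

The compounds shown leave open whether another ring in this place, such as furan-2-yl or pyridin-3-yl, would give a similar number. They also leave open whether thiophen-2-yl would have the same effect on the longer chains of compound 1 and compound 2.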